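Pyrazole in Place of Pyrimidine on the Amide Nitrogen

The source may hold more compounds than are shown below. What is called first, only, known or untested is meant among the compounds shown, and "the series" means these compounds.

In an assay on HEK293 cells for agonist activity at transient receptor potential cation channel subfamily M member 8 (Homo sapiens), read by fluorescence and calcium flux, with a stated time of 15 min (a lower number here means that less compound is needed, a higher number that more compound is needed for the effect), three compounds have been measured:
Compound 1 `Cc1ccc(OCC(=O)N(Cc2cccs2)c2ccn(C)n2)cc1`: 855 nM
Compound 2 `CCC(C)N(Cc1cccs1)C(=O)COc1ccc(C)cc1`: 2000 nM
Compound 3 `Cc1ccc(OCC(=O)N(Cc2cccs2)c2ncccn2)cc1`: 3700 nM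

Compound 3 stands highest of the three. The gap to its nearest neighbour, a 1.9-fold higher number from compound 2 to compound 3 (0.27 log units; within the scatter), lies within the scatter, whereas a 4.3-fold higher number from compound 1 to compound 3 (0.64 log units; beyond the scatter) lies beyond it. Compound 4 `Cc1ccc(OCC(=O)N(Cc2cccs2)c2c[nH]nc2C)cc1` differs from compound 3 by 3-methyl-1H-pyrazol-4-yl in place of pyrimidin-2-yl on an amide-type nitrogen. Going by the values given here, no measured step makes this exact exchange. The step of a 4.3-fold higher number from compound 1 to compound 3 (0.64 log units; beyond the scatter) bears on it, since it runs from a pyrazole to pyrimidin-2-yl; a 2.3-fold higher number from compound 1 to compound 2 (0.37 log units; beyond the scatter) further shows that pyrazole ahead of sec-butyl. A modest move in this assay toward a lower number is therefore expected for compound 4: a 2.3-fold lower number from compound 3 to compound 4 (0.36 log units; beyond the scatter). Compound 4 is estimated at 1600 nM, in a range from 500 nM to 5000 nM.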

Compound 4, half-maximal effective concentration: 0.4 nM
The estimate for compound 4 lay 4000-fold (3.60 log units) above the measured number, and the stated range ends above it.
By their numbers in this assay, from the lowest: compound 4; then compound 1; then compounds 2 and 3 (each within the scatter of the next).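

Going by these compounds alone, at this amide-type nitrogen in this assay, the choice of ring matters far more than the earlier compounds suggested: the step to 3-methyl-1H-pyrazol-4-yl gives a 9300-fold lower number from compound 3 to compound 4 (3.97 log units; beyond the scatter) and a 5000-fold lower number from compound 2 to compound 4 (3.70 log units; beyond the scatter). The pyrazole-to-pyrazole exchange still gives a 2100-fold lower number from compound 1 to compound 4 (3.33 log units; beyond the scatter), so a pyrazole ring alone does not set this result. Among the exchanged groups, 3-methyl-1H-pyrazol-4-yl carries a hydrogen-bond donor, whereas pyrimidin-2-yl has none.

No measurement given here explains the size of this change. The compounds leave open whether an unsubstituted 1H-pyrazol-4-yl or an imidazole ring at this nitrogen would keep such a low number.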